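Amino acid ester variants of a shared lactone core

The compounds below may be only part of what the source reports. "The series", "measured", "known", "first", "only" and "open" are said of these compounds alone.

Measured compounds:
compound 1, `CCCCCCCCCCC[C@@H](C[C@@H]1OC(=O)[C@H]1CCCCCC)OC(=O)[C@@H](N)CC(C)C`: > 50000 nM
compound 2, `CCCCCCCCCCC[C@@H](C[C@@H]1OC(=O)[C@H]1CCCCCC)OC(=O)[C@H](C)NC=O`: > 50000 nM

In an assay on membranes from brain for inhibition of Fatty-acid amide hydrolase 1 (Rattus norvegicus) (a higher number here means a weaker inhibitor, a lower number a stronger inhibitor), compound 1 gives > 50000 nM, which is a limit of the assay and not a number. In this assay compound 2 likewise gives > 50000 nM, again a limit rather than a number. Within the data shown here, compound 2 thus stands at the same limit as the only other value shown, as the limit of > 50000 nM in this assay, at which 2 of the 2 values shown sit, records. The step that the two limits leave unreadable from compound 1 to compound 2 cannot be read in either size or direction, since both ends sit at the limit.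

Compound 3, `CCCCCCCCCCC[C@@H](C[C@@H]1OC(=O)[C@H]1CCCCCC)OC(=O)[C@@H](NC(C)=O)C(C)C`, differs from compound 2 by a group of 8 heavy atoms (6 carbon, 1 nitrogen, 1 oxygen; no ring) in place of a group of 5 heavy atoms (3 carbon, 1 nitrogen, 1 oxygen; no ring), on a carbonyl carbon. Among the measured compounds shown here, the only measured step that touches the same carbonyl carbon is the one from compound 1 to compound 2, and it is unreadable, so the data give no guidance on size or direction for this change. Compound 3 is therefore expected to remain at the same limit, with an expected step of a number no higher from compound 2 to compound 3 (the limit leaves the size open). The estimate for compound 3 in this assay is 50000 nM, with a range from 10000 nM to 200000 nM.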

Compound 3, half-maximal inhibitory concentration: > 50000 nM
Compound 3: only a limit was reported; the forecaster's own chance of this, stated with the estimate: 85%; the middle value sits exactly at the limit.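

In this assay compound 3 gives > 50000 nM, a limit of the assay and not a number. The steps from compound 1 and from compound 2 to compound 3 cannot be read, in size or direction. The compounds shown leave open how these esters of the shared core rank against one another in this assay.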